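Chloro for methyl on the benzylsulfanyl arm of compound 2

This account rests on a few compounds, and the source may have more. Where it says the series, first, only, none or still open, it means among the compounds named here.

Compound 2 `Cc1ccc(CSc2nc3nc(C)cc(Nc4cc(-c5ccccc5)[nH]n4)n3n2)cc1` gives 6960 nM in a functional assay on MGC-803 cells (Homo sapiens) for inhibition, read by MTT assay, with a stated time of 72 h (on this read-out lower numbers stand for stronger inhibition and higher numbers for weaker inhibition), the second highest of the three numbers recorded. Compound 1 `Cc1cc(Nc2ccn(Cc3cccc4ccccc34)n2)n2nc(SCc3ccc(Br)cc3)nc2n1` gives 3240 nM, and compound 3 `Cc1cc(Nc2cc(-c3ccccc3)[nH]n2)n2ncnc2n1` gives 21700 nM. Compound 4 `Cc1cc(Nc2cc(-c3ccccc3)[nH]n2)n2nc(SCc3ccc(Cl)cc3)nc2n1` differs from compound 2 by chloro in place of methyl on an aromatic carbon. Within the data shown here, the one measured step that bears on it is loss of the whole arm, a 3.1-fold higher number from compound 2 to compound 3 (0.49 log units; beyond the scatter), showing that the (4-methylbenzyl)sulfanyl group matters modestly. Among the measured compounds shown here, compound 1, carrying a bromo on a comparable arm but differing from compound 2 in a second place as well, shows a lower number; no single-change step connects them. Swapping one substituent on that arm is expected to move compound 4 by a 1.3-fold lower number from compound 2 to compound 4 (0.10 log units; within the scatter), within the scatter. Compound 4 is therefore estimated at 5500 nM, between 2200 nM and 14000 nM.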

Compound 4, half-maximal inhibitory concentration: 3950 nM
For compound 4 the middle estimate is 1.4-fold (0.14 log units) above the measured one; low and high end bracket the measured number.
By their numbers in this assay, from the lowest: compounds 1, 4 and 2 (each within the scatter of the next, the first and the last beyond it); then compound 3.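

In this assay, the exchange at this position gives a 1.8-fold lower number from compound 2 to compound 4 (0.25 log units; within the scatter), so chloro and methyl are not separated here. The value of the arm no longer rests on the methyl-bearing version alone: the (4-chlorobenzyl)sulfanyl group also gives a step beyond the scatter, a 5.5-fold lower number from compound 3 to compound 4 (0.74 log units; beyond the scatter). No supporting data bear on the reason for either step.

On these data alone, it remains open whether an amine or a carboxylic acid in place of chloro would move the number beyond the scatter. The shown compounds also leave open how an unsubstituted benzyl arm would compare.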